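This account rests on a few compounds, and the source may have more. Where it says the series, first, only, none or still open, it means among the compounds named here.

Of the compounds shown here, three have so far been measured in an in vitro assay on HEK385-7 cells for displacement of a labelled ligand from prostaglandin D2 receptor 2 (Homo sapiens); a lower number here means a stronger inhibitor, a higher number a weaker inhibitor. Compound 1, `O=C(O)Cc1sc(C(c2ccc(F)cc2)c2ccc(F)cc2)nc1-c1ccco1`, gives 18 nM in this assay. Compound 3, `COc1ccc(C(c2ccccc2)c2nc(-c3ccc(Cl)cc3)c(CC(=O)O)s2)cc1`, gives 8.4 nM in this assay, and compound 2, `O=C(O)Cc1sc(C2COc3ccccc3O2)nc1-c1ccc(Cl)cc1`, gives 500 nM in this assay. Among these three numbers compound 1 holds the second highest: it sits nearest to compound 3 and furthest from compound 2, and both gaps lie beyond the usual scatter of repeated measurements.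

The next compound, compound 4, `N#Cc1ccc(-c2nc(C(c3ccc(F)cc3)c3ccc(F)cc3)sc2CC(=O)O)cc1`, has not yet been measured in this assay. It differs from compound 1 in one place: 4-cyanophenyl in place of furan-2-yl on an aromatic carbon. Compound 2 and compound 3 each carry a six-membered aromatic ring of carbon only at the place where compound 1 carries the furan-2-yl, and compound 3 with such a ring gives 8.4 nM in this assay, so a ring of that kind there is compatible with strong binding. For the measured compounds named here, no pair of measured compounds differs in this one place alone, so the size of this step is not known from the data. The step is expected to be small, a 1.2-fold lower number from compound 1 to compound 4 (0.08 log units; within the scatter), and not clearly beyond the usual scatter. Compound 4 is therefore estimated at 15 nM in this assay, within a range from 5 nM to 50 nM.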

Compound 4, half-maximal inhibitory concentration: 150 nM
Compound 4: middle estimate off by 10-fold (1.00 log units), on the low side; measured number above the stated range.
By their numbers in this assay, from the lowest: compound 3; then compound 1; then compound 4; then compound 2.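

In this assay the exchange of furan-2-yl for 4-cyanophenyl on the aromatic carbon next to the ring nitrogen gives an 8.3-fold higher number from compound 1 to compound 4 (0.92 log units; beyond the scatter) and shows that this position is sensitive to the group it carries. For the compounds shown here, this is the first step at this place that can be read on its own, since the earlier compounds differ from one another in more than one place and could not give its size. No measurement shown accounts for the weaker binding of compound 4, so the step stands as an observation without a known cause.

The change replaces a five-membered aromatic ring with a six-membered aromatic ring of carbon only and adds a nitrile in the same move, so the compounds shown cannot separate the contribution of the ring from that of the nitrile. As far as these compounds go, it remains open whether an unsubstituted phenyl ring or a thiophene ring at this place, on the core of compound 1, would bind like compound 1 or like compound 4.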